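The compounds below may be only part of what the source reports. "The series", "measured", "known", "first", "only" and "open" are said of these compounds alone.

Compound 1 `N#CC1=C(N)OC(c2c[nH]c3ccccc23)=C(C#N)C1c1ccc(Br)cc1`, compound 3 `N#CC1=C(N)OC(c2c[nH]c3ccccc23)=C(C#N)C1c1ccc(F)cc1`, compound 2 `N#CC1=C(N)OC(c2c[nH]c3ccccc23)=C(C#N)C1c1ccc2ccccc2c1` and the still unmeasured compound 4 `N#CC1=C(N)OC(c2c[nH]c3ccccc23)=C(C#N)C1c1cccc2ccccc12` share one core and differ only in the group on the saturated ring carbon. In a functional assay, tested at 200 ug/mL (on this read-out lower numbers stand for a weaker effect and higher numbers for a stronger effect at the one concentration tested), compound 1 gives 10.6%, the lowest of the two numbers reported. Compound 3 gives 22.4%, and the step of a number 11.8 percentage points higher from compound 1 to compound 3 (beyond the scatter) lies beyond the scatter. Compound 2 gives "not active" (no number reported), with no number reported. The change to compound 4 is naphthalen-1-yl in place of 4-bromophenyl on a saturated ring carbon. Among the measured compounds shown here, no measured step covers this exchange: the only known step swaps fluoro for bromo, while compound 2, the nearest measured neighbour of compound 4 in structure, shows no activity. Compound 4 is therefore expected to stay low, with a number 4.6 percentage points lower from compound 1 to compound 4 (within the scatter) amounting to no gain. The estimated value of compound 4 is 6%, between 0% and 16%.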

Compound 4, a percentage reported as activity, at one concentration (the size of the read-out at that concentration, not a potency): 7.7%
Beside the measured number, compound 4's estimate is 1.7 percentage points below it; measured number inside the range.
By their numbers in this assay, from the lowest: compounds 4 and 1 (each within the scatter of the next); then compound 3.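

In this assay naphthalen-1-yl on the saturated ring carbon stays level with 4-bromophenyl (a number 2.9 percentage points lower from compound 1 to compound 4 (within the scatter)), so this position accepts the larger group with two aromatic rings without leaving the scatter of compound 1. Set against 4-fluorophenyl, the same exchange gives a lower number (a number 14.7 percentage points lower from compound 3 to compound 4 (beyond the scatter)), which leaves compound 3 above both other numbered compounds. No evidence is available to explain these results.

From the compounds shown here alone, what an amine or a carboxylic acid on the phenyl ring would do at this position remains open.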